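Aryl ether swap: chlorophenyl to naphthyl in compound 4

The compounds below may be only part of what the source reports. "The series", "measured", "known", "first", "only" and "open" are said of these compounds alone.

Compound 1 `O=C(CSc1nc2ccccc2s1)N/N=C/c1ccc(Oc2ccc(Cl)cc2)cc1` gives 5.6 in a physicochemical assay for lipophilicity, in phosphate buffer, measured as octanol-water partition, with a stated time of 24 h (a lower number here means a more polar compound, a higher number a more lipophilic compound), the highest of the three measured numbers. Compound 2 `Brc1ccc(Oc2ccc(/C=N/Nc3nc4ccccc4s3)cc2)cc1` gives 5.5, within the scatter of compound 1, and compound 3 `Fc1ccc(Oc2ccc(/C=N/Nc3nc4ccccc4s3)cc2)cc1` gives 5, beyond the scatter below compound 1. Going by the values given here, the one measured single-point step, a number 0.50 log units lower from compound 2 to compound 3 (beyond the scatter), concerns a halogen swap only.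

Compound 4 `O=C(CSc1nc2ccccc2s1)N/N=C/c1ccc(Oc2ccc3ccccc3c2)cc1` arises from compound 1 by naphthalen-2-yl in place of 4-chlorophenyl on an oxygen on an aromatic ring. Among the compounds with values here, no measured step covers such a ring change, so the expectation rests on compound 1 alone. Compound 4 is expected to sit somewhat higher, a step of a number 0.40 log units higher from compound 1 to compound 4 (beyond the scatter) in this assay, with the estimate for compound 4 at 6 (range 5.5 to 6.5).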

Compound 4, partition coefficient: 5.9
Estimate against measurement, compound 4: 0.10 log units above; low and high end bracket the measured number.
By their numbers in this assay, from the lowest: compound 3; then compounds 2, 1 and 4 (each within the scatter of the next, the first and the last beyond it).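

In this assay, going by these compounds alone, the first ring change at this place gives a step that stays inside the scatter: naphthalen-2-yl in place of 4-chlorophenyl on an oxygen on an aromatic ring (a number 0.30 log units higher from compound 1 to compound 4 (within the scatter)). The earlier compounds shown here offered only a halogen swap, whereas this pair shows that two six-membered aromatic rings of carbon only can replace one chlorine-bearing ring without a step beyond the scatter. Nothing measured here explains this result. The compounds shown leave open how this assay would read with an aminophenyl or carboxyphenyl group on this oxygen.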